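The source may report more compounds than this note shows. Statements on the series, on what has been measured and on what is new or still open speak of the compounds shown alone.

Measured in an assay on membranes from brain for displacement of a labelled ligand from Neuronal acetylcholine receptor; alpha4/beta2 (Rattus norvegicus), with a stated time of 3 h; a lower number here means a stronger inhibitor, a higher number a weaker inhibitor:

Compound 1, `CC(C)(C)C(=O)Oc1ccccc1/C=C1\CCCN=C1c1cccnc1`: 1440 nM
Compound 2, `CCCCOc1ccc(/C=C2\CCCN=C2c2cccnc2)cc1`: 1960 nM
Compound 3, `COc1ccc(/C=C2\CCCN=C2c2cccnc2)c(OC)c1`: 250 nM

Among these three numbers compound 2 stands highest. Its gap to compound 1 lies within the scatter, so the two cannot be ordered; compound 3 sits well below it, a gap beyond the scatter. Compound 4, `CC(C)(C)C(=O)Oc1ccc(/C=C2\CCCN=C2c2cccnc2)cc1`, is not yet measured. It differs from compound 2 by (tert-butyl)carbonyl in place of butyl on an oxygen on an aromatic ring. Within the data shown here, no pair of measured compounds differs in one place, so no step of this kind has been seen. Compound 1 carries the same entering group and gives 1440 nM, close to compound 2. The step from compound 2 to compound 4 in this assay is therefore expected to be a 1.3-fold lower number from compound 2 to compound 4 (0.12 log units; within the scatter), nothing beyond the scatter. Compound 4 is estimated at 1500 nM, in the range 600 nM to 4000 nM.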

Compound 4, inhibition constant: 830 nM
Compound 4: middle estimate off by 1.8-fold (0.26 log units), on the high side; low and high end bracket the measured number.
By their numbers in this assay, from the lowest: compound 3; then compounds 4, 1 and 2 (each within the scatter of the next, the first and the last beyond it).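

Within this assay the change from butyl to (tert-butyl)carbonyl on an oxygen on an aromatic ring gives a 2.4-fold lower number from compound 2 to compound 4 (0.37 log units; beyond the scatter) and is the only single-place step shown. It shows that the number responds to the group on this oxygen, and that an entering group with a carbonyl and a hydrogen-bond acceptor is tolerated here without loss. Nothing measured here accounts for the step. The compounds shown leave open whether the carbonyl or the branched tert-butyl carries the step, and how a smaller acetyl or a free hydroxyl would read at this place.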